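Hydroxy for methoxy on the shared core

The source may hold more compounds than are shown below. What is called first, only, known or untested is meant among the compounds shown, and "the series" means these compounds.

Among the measured compounds shown here, compound 1 `COc1cc(/C=N/NC(=O)c2ccncc2)cc(OC)c1O` gives the higher of the two numbers measured so far in a physicochemical assay on cells (Homo sapiens), with a stated time of 18 h, tested at 10 uM (on this read-out higher numbers stand for a weaker effect at the one concentration tested and lower numbers for a stronger effect), at 7%. Its nearest neighbour, compound 2 `COc1cc(/C=N/NC(=O)OCc2ccccc2)cc(OC)c1O`, gives 3% in this assay, and the step of a number 4 percentage points lower from compound 1 to compound 2 (within the scatter), benzyloxy in place of pyridin-4-yl on a carbonyl carbon, lies within the scatter. Compound 3 `COc1cc(/C=N/NC(=O)c2ccncc2)cc(O)c1O` differs from compound 1 in one place: hydrogen in place of methyl on an oxygen on an aromatic ring. For the measured compounds named here, no measured step touches this part of the structure; the only step recorded, a number 4 percentage points lower from compound 1 to compound 2 (within the scatter), concerns the carbonyl side and was within the scatter. Both measured compounds already sit at low values, leaving little room downward. Compound 3 is therefore expected to show a step of a number 3 percentage points higher from compound 1 to compound 3 (within the scatter) in this assay, not clearly beyond the scatter. The estimate for compound 3 is 10%, ranging from 2% to 30%.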

Compound 3, a percentage reported as activity, at one concentration (the size of the read-out at that concentration, not a potency): 8%
For compound 3 the middle estimate is 2 percentage points above the measured one, and the stated range covers the measured number.
By their numbers in this assay, from the lowest: compounds 2, 1 and 3 (each within the scatter of the next).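

In this assay the change from methoxy to hydroxy gives the first step read at this position, a number 1 percentage points higher from compound 1 to compound 3 (within the scatter), so hydrogen in place of methyl on this oxygen does not move the read-out beyond the scatter in the setting of compound 1. With pyridin-4-yl kept on the carbonyl carbon, the methyl on this oxygen is therefore not needed to keep the number in the low range seen for compound 1. No measurement shown here gives a reason for this result.

The compounds shown leave open whether a longer chain such as ethyl, or a chain ending in an amine or a carboxylic acid, on this oxygen would take the number beyond the scatter. They also leave open whether the same change would read alike with benzyloxy on the carbonyl carbon, as in compound 2.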